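Fluoro for hydroxy on the methoxy-bearing ring

This account rests on a few compounds, and the source may have more. Where it says the series, first, only, none or still open, it means among the compounds named here.

In a functional assay on M14 cells (Homo sapiens) for inhibition (on this read-out lower numbers stand for stronger inhibition of growth and higher numbers for weaker inhibition of growth), compound 1 (`COc1ccc(-n2cnnc2-c2cc(OC)c(OC)c(OC)c2)cc1`) gives 1950 nM and compound 2 (`COc1ccc(-n2cnnc2-c2cc(OC)c(OC)c(OC)c2)cc1O`) gives 295 nM as the lower of the two numbers. Compound 3 (`COc1ccc(-n2cnnc2-c2cc(OC)c(OC)c(OC)c2)cc1F`) has fluoro in place of hydroxy on an aromatic carbon, ortho to a methoxy group and meta to a large group: fluoro in place of hydroxy on an aromatic carbon is the whole change. Within the data shown here, only one measured step bears on this carbon: a 6.6-fold lower number from compound 1 to compound 2 (0.82 log units; beyond the scatter) on introducing the hydroxy, a modest step. Among the measured compounds shown here, no fluoro compound has been measured, so the expectation rests on that single step. Removing the hydroxy is expected to give back much of that gain, though not necessarily all of it. The expected step is a 3.1-fold higher number from compound 2 to compound 3 (0.48 log units; beyond the scatter) in the direction of a higher number. For compound 3 the estimate is 900 nM with an expected range of 250 nM to 3000 nM in this series.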

Compound 3, concentration for 50% growth inhibition: 2240 nM
For compound 3 the middle estimate is 2.5-fold (0.40 log units) below the measured one, and the stated range covers the measured number.
By their numbers in this assay, from the lowest: compound 2; then compounds 1 and 3 (each within the scatter of the next).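

In this assay, fluoro in place of hydroxy gives a 7.6-fold higher number from compound 2 to compound 3 (0.88 log units; beyond the scatter), so the lower number seen with compound 2 does not carry over to fluoro at this carbon. Fluoro in place of hydrogen gives a 1.1-fold higher number from compound 1 to compound 3 (0.06 log units; within the scatter), so this read-out does not separate fluoro from hydrogen here, and of the three groups tried at this carbon only hydroxy stands apart. Nothing available explains why the hydroxy differs from the other two groups.

Open, on these data alone, is whether an amino group or a chloro group at this carbon would give a number near that of compound 2 or near those of compound 1 and compound 3. Also open, as far as these compounds go, is whether the hydroxy step would hold with an ethoxy group in place of the neighbouring methoxy group.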